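Trimming One Methoxy Group from Compound 1

The source may report more compounds than this note shows. Statements on the series, on what has been measured and on what is new or still open speak of the compounds shown alone.

Of the compounds shown here, three that share one core have been tested in a functional assay on NCI-H226 cells (Homo sapiens) for inhibition, read by sulforhodamine B assay, with a stated time of 48 h; on this read-out higher numbers stand for weaker inhibition of growth and lower numbers for stronger inhibition of growth. Compound 1 `COc1ccc(CNc2nc3cc(N)cc(N)c3nc2-c2ccccc2)cc1OC` gives 14500 nM. Compound 2 `CCOC(=O)[C@H](CCC(=O)O)NC(=O)c1ccc(Sc2nc3cc(N)cc(N)c3nc2-c2ccccc2)cc1` gives 17800 nM, and compound 3 `COc1cc(CNc2nc3cc(N)cc(N)c3nc2-c2ccccc2)cc(OC)c1OC` gives 10000 nM. Compound 1 stands second highest of the three numbers, yet its gap to compound 2 and its gap to compound 3 both lie within the scatter of repeated measurements, and the three cannot be told apart.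

Compound 4 `COc1ccc(CNc2nc3cc(N)cc(N)c3nc2-c2ccccc2)cc1` has not been measured. It differs from compound 1 in one place: hydrogen in place of methoxy on an aromatic carbon. Among the measured compounds shown here, only one measured step bears on this change, and it runs the other way: a 1.5-fold lower number from compound 1 to compound 3 (0.16 log units; within the scatter), an added methoxy group rather than a removed one. That addition stayed within the scatter, and removing a methoxy group is expected to do about the same. Compound 4 is therefore estimated to give 16000 nM in this assay, with a range from 7000 nM to 35000 nM. That would be an expected step of a 1.1-fold higher number from compound 1 to compound 4 (0.04 log units; within the scatter), staying within the scatter.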

Compound 4, concentration for 50% growth inhibition: 20400 nM
Compound 4: the middle estimate sits 1.3-fold (0.11 log units) below what was measured, within the range that was stated.
By their numbers in this assay, from the lowest: compounds 3, 1, 2 and 4 (each within the scatter of the next, the first and the last beyond it).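

Among the compounds shown here, compound 4 gives the first direct reading of taking a methoxy group away, as 3,4-dimethoxyphenyl becomes 4-methoxyphenyl in this assay (a 1.4-fold higher number from compound 1 to compound 4 (0.15 log units; within the scatter)). The earlier compounds shown here showed only a methoxy group being added to this ring (a 1.5-fold lower number from compound 1 to compound 3 (0.16 log units; within the scatter)), so it is now clear that a single methoxy change in either direction from compound 1 stays within the scatter. At this position, hydrogen and methoxy cannot be told apart on this read-out, and no available measurement explains that result.

The compounds shown leave open whether a different group on this aromatic carbon, such as an amine, a carboxylic acid or a longer ether chain, would shift the number beyond the scatter. They also leave open what happens when the remaining methoxy group of compound 4 is replaced by hydrogen.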